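The source may hold more compounds than are shown below. What is called first, only, known or untested is meant among the compounds shown, and "the series" means these compounds.

In a functional assay on DU-145 cells (Homo sapiens) for antiproliferative activity, read by WST assay, with a stated time of 3 days (a lower number here means a stronger inhibitor, a higher number a weaker inhibitor), compound 1 `CCCCCOc1c(-c2cc(OC)c(OC)c(OC)c2)oc2ccccc2c1=O` gives only a limit, > 50000 nM. Compound 2 `CCN(CC)CCCCCOc1c(-c2cc(OC)c(OC)c(OC)c2)oc2ccccc2c1=O` reads 33400 nM, and the step is an at least 1.4-fold lower number from compound 1 to compound 2 (0.17 log units; that floor lies within the scatter). Compound 3 `CCCCN(CCCC)CCCCCOc1c(-c2cc(OC)c(OC)c(OC)c2)oc2ccccc2c1=O` also gives only a limit, > 50000 nM. That leaves an at least 1.4-fold higher number from compound 2 to compound 3 (0.17 log units; that floor lies within the scatter), and a step that the two limits leave unreadable from compound 1 to compound 3. Compound 4 `CCCCCN(CCCCC)CCCCOc1c(-c2cc(OC)c(OC)c(OC)c2)oc2ccccc2c1=O` differs from compound 3 by dipentylamino in place of (dibutylamino)methyl on a saturated chain carbon, four bonds along the chain from an oxygen on an aromatic ring. The steps to compound 2 and compound 3 bear on this change, and neither is shown beyond the scatter, while the series stays close to the limit of > 50000 nM in this assay, at which 2 of the 3 values shown sit. No step beyond the scatter is therefore expected in this assay, in either direction. The expected step is an at least 1.2-fold lower number from compound 3 to compound 4 (0.09 log units; that floor lies within the scatter). Compound 4 is estimated at 40000 nM, with an expected range of 15000 nM to 70000 nM.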

Compound 4, half-maximal inhibitory concentration: 12500 nM
The estimate for compound 4 lay 3.2-fold (0.51 log units) above the measured number, outside the stated range (below it).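

In this assay, among these compounds, dipentylamino at this place, four bonds along the chain from an oxygen on an aromatic ring, gives the first readable step beyond the scatter: a 2.7-fold lower number from compound 2 to compound 4 (0.43 log units; beyond the scatter). The other two steps, an at least 4.0-fold lower number from compound 3 to compound 4 (0.60 log units; beyond the scatter) and an at least 4.0-fold lower number from compound 1 to compound 4 (0.60 log units; beyond the scatter), are also beyond the scatter, but both are floors set by a limit rather than by a number: the limit of > 50000 nM in this assay, at which 2 of the 4 values shown sit.

The compounds shown change the chain and the amine together and do not separate the two. Going by these compounds, how a piperidine or a dihexylamino group would read at this place remains open.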